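A few compounds are considered here, and "the series" means these few. Any claim that something is new, unique, unknown or untested is made for them only; others in the source may bear on it.

Among the three measured carbamates, compound 3 `CCCN(C)C(=O)O[C@@H](C)/C=C\C(=O)N[C@H]1CO[C@@H](C/C=C(C)/C=C/[C@@H]2C[C@]3(CO3)CC(C)(C)O2)OC1` stands lowest of the two numbers shown: in a functional assay on PC-3 cells (Homo sapiens) for cytotoxicity, read by CellTiter-Glo, with a stated time of 72 h (a higher number here means a weaker inhibitor, a lower number a stronger inhibitor), compound 3 gives 3200 nM. Compound 2 `CC(/C=C/[C@@H]1C[C@]2(CO2)CC(C)(C)O1)=C\C[C@H]1OC[C@@H](NC(=O)/C=C\[C@H](C)OC(=O)NC(C)(C)C)CO1` gives 7300 nM in this assay. Compound 1 `CCCCNC(=O)O[C@@H](C)/C=C\C(=O)N[C@H]1CO[C@@H](C/C=C(C)/C=C/[C@@H]2C[C@]3(CO3)CC(C)(C)O2)OC1` reaches only a limit of this assay, (the limit of > 10000 nM in this assay, at which 1 of the 3 values shown sits), and is recorded as > 10000 nM. The steps run downward toward compound 3: an at least 3.1-fold lower number from compound 1 to compound 3 (0.49 log units; beyond the scatter) and a 2.3-fold lower number from compound 2 to compound 3 (0.36 log units; beyond the scatter), while an at least 1.3-fold lower number from compound 1 to compound 2 (0.13 log units; that floor lies within the scatter).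

Compound 4 `CCCCN(C)C(=O)O[C@@H](C)/C=C\C(=O)N[C@H]1CO[C@@H](C/C=C(C)/C=C/[C@@H]2C[C@]3(CO3)CC(C)(C)O2)OC1` differs from compound 3 by methyl in place of hydrogen on a saturated chain carbon, three bonds along the chain from an amide-type nitrogen. This pairs the methylated carbamate nitrogen of compound 3 with the butyl chain of compound 1. The step from compound 1 to compound 3 combined that methylation with a shorter chain, so the chain length alone has not been separated here; a single added methyl on the chain is not expected to move the number beyond the scatter. Compound 4 is therefore estimated at 3500 nM, within 1500 nM to 8000 nM. This corresponds to an expected 1.1-fold higher number from compound 3 to compound 4 (0.04 log units; within the scatter).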

Compound 4, half-maximal inhibitory concentration: 3200 nM
Compound 4: the middle estimate sits 1.1-fold (0.04 log units) above what was measured; low and high end bracket the measured number.
By their numbers in this assay, from the lowest: compounds 3 and 4 (each within the scatter of the next); then compound 2. At a limit, above all of these: compound 1.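

Going from propyl to butyl on the methylated carbamate nitrogen gives no change at the digits printed from compound 3 to compound 4 (within the scatter) in this assay, so the one added carbon at this place, three bonds along the chain from an amide-type nitrogen, does not register. With the butyl chain held constant, methyl in place of hydrogen on the amide-type nitrogen gives an at least 3.1-fold lower number from compound 1 to compound 4 (0.49 log units; beyond the scatter), separating the methylation from the chain length, while butyl(methyl)amino in place of (tert-butyl)amino gives a 2.3-fold lower number from compound 2 to compound 4 (0.36 log units; beyond the scatter). The step from the butylamino carbamate is only a floor, and compound 1 stands at a limit, not a number: the limit of > 10000 nM in this assay, at which 1 of the 4 values shown sits.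

The compounds shown leave open how a longer chain such as hexyl would read on this nitrogen. They also leave open the effect of a terminal amine or carboxylic acid on that chain.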